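Compound 3: A New Group on the Chain Carbon

The source may hold more compounds than are shown below. What is called first, only, known or untested is meant among the compounds shown, and "the series" means these compounds.

Compound 1 `C[C@@H](c1ccc(NC(=O)N2CC(c3ccc(N)nc3)C2)cc1)N1Cc2ccccc2C1=O`: 19 nM
Compound 2 `C[C@@H](c1ccc(NC(=O)N2CC(c3cncc(N)c3)C2)cc1)N1Cc2ccccc2C1=O`: 130 nM

Within the data shown here, in a functional assay on COR-L23 cells (Homo sapiens) for antiproliferative activity, read by CellTiter-Glo, with a stated time of 72 h (on this read-out lower numbers stand for stronger inhibition and higher numbers for weaker inhibition), compound 2 gives 130 nM, the higher of the two numbers measured so far. Compound 3 `C[C@H](NC(=O)[C@@H]1CCCN1C)c1ccc(NC(=O)N2CC(c3cncc(N)c3)C2)cc1` differs from it by one change: a group of 9 heavy atoms (6 carbon, 2 nitrogen, 1 oxygen; one five-membered non-aromatic ring with 1 hetero atom) in place of a group of 10 heavy atoms (8 carbon, 1 nitrogen, 1 oxygen; one five-membered non-aromatic ring with 1 hetero atom, one six-membered aromatic ring of carbon only), on a saturated chain carbon bound to an aromatic carbon and a saturated chain carbon. The entering group is ((1-methylpyrrolidin-2-yl)carbonyl)amino, and neither measured compound carries it. Among the measured compounds shown here, the only measured step, a 6.8-fold higher number from compound 1 to compound 2 (0.84 log units; beyond the scatter), places 5-aminopyridin-3-yl where 6-aminopyridin-3-yl stood, so it concerns a different place in the molecule. It bears on the new change only as a guide to size, showing that one change in this pair moved the number beyond the scatter. It gives no direction for the new change. A modest move towards a higher number is expected, with wide uncertainty. The expected step in this assay is a 2.7-fold higher number from compound 2 to compound 3 (0.43 log units; beyond the scatter). For compound 3 the estimated value is 350 nM, with an expected range of 70 nM to 1800 nM.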

Compound 3, half-maximal inhibitory concentration: 200 nM
Compound 3: middle estimate off by 1.8-fold (0.24 log units), on the high side, within the range that was stated.
By their numbers in this assay, from the lowest: compound 1; then compounds 2 and 3 (each within the scatter of the next).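

In this assay the exchange on the saturated chain carbon gives a 1.5-fold higher number from compound 2 to compound 3 (0.19 log units; within the scatter) and so leaves ((1-methylpyrrolidin-2-yl)carbonyl)amino and the group it replaces indistinguishable on this read-out. Among these compounds, the one earlier step concerned the aminopyridine on the saturated ring carbon, so this is the first reading at the chain carbon, and it shows that the number holds there without the six-membered aromatic ring of carbon only, with 5-aminopyridin-3-yl kept in place. No measurement shown here accounts for this result.

Going by these compounds, whether the same exchange would read alike with the 6-aminopyridin-3-yl of compound 1 remains open, as does the role of the defined stereocentre in the entering group. On these data alone, it is also open whether a smaller acetylamino group or a free primary amine on that chain carbon would give a number apart from these.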